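This account rests on a few compounds, and the source may have more. Where it says the series, first, only, none or still open, it means among the compounds named here.

Of the compounds shown here, three of a shared core have been measured in a functional assay on DU-145 cells (Homo sapiens) for inhibition, read by trypan blue exclusion, with a stated time of 96 h; on this read-out higher numbers stand for weaker inhibition of growth and lower numbers for stronger inhibition of growth. Compound 1 `COc1ccc(C(=O)/C(=C\c2ccc(OC)c(O)c2)Sc2ccc(F)cc2)cc1` gives 1000 nM in this assay. Compound 2 `Cc1ccc(C)c(/C=C(/Sc2ccc(Br)cc2)C(=O)c2ccc(Cl)cc2)c1` gives 10000 nM, and compound 3 `O=C(/C(=C\c1csc([N+](=O)[O-])c1)S(=O)(=O)c1ccc(Br)cc1)c1ccc(Br)cc1` gives 1000 nM.

Compound 3 stands level with compound 1 at the digits shown, a gap within the usual scatter, and the two together give the lowest numbers of the three. Compound 2 sits furthest away, with a number that is higher than that of compound 3 by an amount clearly beyond the scatter.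

Compound 4 `Nc1c(Br)cc(Br)cc1/C=C(\C(=O)c1ccc(Br)cc1)S(=O)(=O)c1ccc(Br)cc1` has not yet been measured in this assay. It differs from compound 3 in one place: 2-amino-3,5-dibromophenyl in place of 5-nitrothiophen-3-yl on a double-bonded chain carbon bound to a double-bonded chain carbon. Going by the values given here, no measured pair shows this change on its own, so nothing in the data ties it to a definite step. Compound 4 is therefore expected to stay within the scatter of compound 3, so that the step of a 1.5-fold higher number from compound 3 to compound 4 (0.18 log units; within the scatter) is estimated as small. For compound 4 the estimated value in this assay is 1500 nM, within a range from 400 nM to 6000 nM.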

Compound 4, concentration for 50% growth inhibition: 25000 nM
Compound 4: the middle estimate sits 17-fold (1.22 log units) below what was measured; the measured number lies above the stated range.
By their numbers in this assay, from the lowest: compounds 1 and 3 (each within the scatter of the next); then compound 2; then compound 4.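

In this assay, the group on a double-bonded chain carbon bound to a double-bonded chain carbon clearly matters: putting 2-amino-3,5-dibromophenyl in place of 5-nitrothiophen-3-yl gives a 25-fold higher number from compound 3 to compound 4 (1.40 log units; beyond the scatter). Going by these compounds alone, this is the only pair here that differs in one place, so it is the only direct view of this position, and it shows that growth inhibition can weaken sharply with the rest of compound 3 unchanged. Nothing measured here explains the size of this step.

On these data alone, the change swaps the ring and the groups on it all at once, so it remains open whether the new ring, the departure of the nitro group, or the arrival of the amino group and bromines drives the step. An unsubstituted phenyl group at this position would help to separate the ring from the groups it carries.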